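The compounds below may be only part of what the source reports. "The series", "measured", "known", "first", "only" and "open" are said of these compounds alone.

Measured compounds in a functional assay on MGC-803 cells (Homo sapiens) for antiproliferative activity, read by MTT assay, with a stated time of 72 h; on this read-out higher numbers stand for weaker inhibition and lower numbers for stronger inhibition:
compound 1 `O=C(NO)c1ccc(NCc2nc(-c3ccccc3)nn2-c2ccc(F)cc2)cc1` — 10500 nM
compound 2 `O=C(NO)c1ccc(NCc2nc(-c3cccc(Cl)c3)nn2-c2ccccc2)cc1` — 5760 nM
compound 3 `Cc1ccc(-c2nc(CNc3ccc(C(=O)NO)cc3)n(-c3ccccc3)n2)s1` — 8450 nM

Compound 3 stands second highest of the three numbers in this assay; its gap to compound 1 and its gap to compound 2 each lie within the scatter, so no order among the three is drawn. Compound 4 `O=C(NO)c1ccc(NCc2nc(-c3ccccc3)nn2-c2ccccc2)cc1` differs from compound 3 by phenyl in place of 5-methylthiophen-2-yl on an aromatic carbon. Going by the values given here, one measured step bears on this position: the change from compound 2 to compound 3, a 1.5-fold higher number from compound 2 to compound 3 (0.17 log units; within the scatter), which stayed within the scatter. Compound 1 also carries phenyl at this position, though with a different group on the ring nitrogen, and its number lies close to that of compound 3. The expectation is therefore a step no larger than the scatter, a 1.1-fold higher number from compound 3 to compound 4 (0.03 log units; within the scatter). Compound 4 is estimated at 9000 nM, with a range from 4000 nM to 20000 nM.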

Compound 4, half-maximal inhibitory concentration: 17700 nM
The estimate for compound 4 lay 2.0-fold (0.29 log units) below the measured number; measured number inside the range.
By their numbers in this assay, from the lowest: compounds 2, 3, 1 and 4 (each within the scatter of the next, the first and the last beyond it).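

In this assay, going by these compounds alone, phenyl in place of 5-methylthiophen-2-yl gives the first step beyond the scatter at this position (a 2.1-fold higher number from compound 3 to compound 4 (0.32 log units; beyond the scatter)), so the two rings are not interchangeable here. Chloro on the aromatic ring also registers: hydrogen in its place gives a step beyond the scatter (a 3.1-fold higher number from compound 2 to compound 4 (0.49 log units; beyond the scatter)), while hydrogen in place of fluoro stays within it (a 1.7-fold higher number from compound 1 to compound 4 (0.23 log units; within the scatter)). No measured data accounts for these steps.

Open, from the compounds shown here alone, is whether thiophen-2-yl without its methyl matches compound 3. An amine or a carboxylic acid on the phenyl also remains untested in the compounds shown.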